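Extending an Amino Substituent from Hydrogen to Propyl

The source may hold more compounds than are shown below. What is called first, only, known or untested is meant among the compounds shown, and "the series" means these compounds.

Measured compounds:
- Compound 1 `CNc1nc(Nc2ccc(C#N)cc2)nc(Oc2cccc3ccccc23)n1`: 30300 nM
- Compound 2 `N#Cc1ccc(Nc2nc(N)nc(Oc3cccc4ccccc34)n2)cc1`: 39100 nM

In an ADME assay on MT4 cells (Homo sapiens) for cytotoxicity, read by MTT assay, with a stated time of 4 days (on this read-out higher numbers stand for lower toxicity in this test and lower numbers for higher toxicity in this test), compound 2 gives 39100 nM, and compound 1 gives 30300 nM in this assay; the two values are indistinguishable within the scatter, so compound 2 stands alongside compound 1 rather than apart from it. Compound 3 `CCCNc1nc(Nc2ccc(C#N)cc2)nc(Oc2cccc3ccccc23)n1` has not yet been measured. It differs from compound 2 by propyl in place of hydrogen on a nitrogen on an aromatic ring. Going by the values given here, the only measured step that speaks to this change is a 1.3-fold higher number from compound 1 to compound 2 (0.11 log units; within the scatter), which swaps hydrogen and methyl at the same nitrogen and leaves the number essentially where it was. A propyl at this position is a larger change than a methyl, but nothing measured here shows that such a change moves this assay; the expectation is therefore a step no larger than the scatter, with a 1.3-fold lower number from compound 2 to compound 3 (0.12 log units; within the scatter) as the estimated shift. Compound 3 is thus expected to give about 30000 nM in this assay, within a range of 12000 nM to 75000 nM.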

Compound 3, half-maximal cytotoxic concentration: 29500 nM
Compound 3: middle estimate off by 1.0-fold (0.01 log units), on the high side; the measured number falls inside the stated range.
By their numbers in this assay, from the lowest: compounds 3, 1 and 2 (each within the scatter of the next).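

Compound 1 and compound 2 showed only that a methyl or a hydrogen on this nitrogen gives much the same number, and compound 3 tests a longer chain at the same place. In this assay the change from amino to propylamino gives a 1.3-fold lower number from compound 2 to compound 3 (0.12 log units; within the scatter) and the ethyl added to the methyl of compound 1 gives a 1.0-fold lower number from compound 1 to compound 3 (0.01 log units; within the scatter) and so, with both steps within the scatter, this nitrogen has so far tolerated hydrogen, methyl and propyl alike in this test. Nothing available here explains why the number holds steady.

Going by these compounds, whether a much longer chain, a cyclohexyl ring, or a chain ending in an amine or a carboxylic acid would also leave the number within the scatter stays open. On these data alone, it is also open whether the same holds with a different group in place of the nitrile.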